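Methoxypyridinyl for pyrimidinyl in the lipophilicity series

The source may report more compounds than this note shows. Statements on the series, on what has been measured and on what is new or still open speak of the compounds shown alone.

Compound 1 `O=C(O)C[C@H](CCCCCCc1ccc2c(n1)NCCC2)c1cncnc1` stands lowest of the two measured compounds in a physicochemical assay for lipophilicity (on this read-out lower numbers stand for lower lipophilicity and higher numbers for higher lipophilicity), giving 0.1. Among the compounds with values here, compound 2 `COc1ncc([C@@H](CCCCCCc2ccc3c(n2)NCCC3)CC(=O)O)cn1` gives 0.65 in this assay, and the step of a number 0.55 log units higher from compound 1 to compound 2 (beyond the scatter) is the only measured step available. Compound 3 `COc1ccc([C@@H](CCCCCCc2ccc3c(n2)NCCC3)CC(=O)O)cn1` carries the change (6-methoxypyridin-3-yl in place of pyrimidin-5-yl on a saturated chain carbon bound to two saturated chain carbons). Within the data shown here, the methoxy part of this exchange matches the measured step, so an increase of at least that size is expected; the remaining part of the ring exchange is covered by no measured pair. Compound 3 is therefore expected to rise by a number 0.90 log units higher from compound 1 to compound 3 (beyond the scatter), to an estimated 1 in this assay, within 0.5 to 1.5.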

Compound 3, partition coefficient: 1.67
Compound 3: middle estimate off by 0.67 log units, on the low side; the whole stated range lies below it.
By their numbers in this assay, from the lowest: compound 1; then compound 2; then compound 3.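

In this assay, the exchange on a saturated chain carbon bound to two saturated chain carbons gives a number 1.57 log units higher from compound 1 to compound 3 (beyond the scatter) for 6-methoxypyridin-3-yl in place of pyrimidin-5-yl. With methoxy on both rings, 6-methoxypyridin-3-yl in place of 2-methoxypyrimidin-5-yl still gives a number 1.02 log units higher from compound 2 to compound 3 (beyond the scatter) in this series, so the methoxy step alone does not cover the exchange and the ring itself also counts at this position. No available evidence bears on the origin of this result.

Open, going by these compounds, is whether ethoxy or an amine in place of the methoxy of 6-methoxypyridin-3-yl would move the number in the same direction.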